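Nitro to amino on compound 1

A few compounds are considered here, and "the series" means these few. Any claim that something is new, unique, unknown or untested is made for them only; others in the source may bear on it.

Measured in a functional assay on HCT-15 cells (Homo sapiens) for antiproliferative activity, read by MTT assay, with a stated time of 72 h; a lower number here means a stronger inhibitor, a higher number a weaker inhibitor:
compound 1 `COc1ccc(-n2ccnc2-c2cc(OC)c(OC)c(OC)c2)cc1[N+](=O)[O-]` gives 1000 nM
compound 2 `COc1cc(-c2nccn2-c2cccc([N+](=O)[O-])c2)cc(OC)c1OC` gives > 100000 nM as a limit of the assay
compound 3 `COc1cc(-c2nccn2-c2ccc(Br)cc2)cc(OC)c1OC` gives 11700 nM

Compound 1 stands lowest of the three, with compound 3 nearest to it at 11700 nM. Compound 4 `COc1ccc(-n2ccnc2-c2cc(OC)c(OC)c(OC)c2)cc1N` carries amino in place of nitro on an aromatic carbon, ortho to a methoxy group (amino in place of nitro on an aromatic carbon). Compound 1 has one measured step, hydrogen in place of methoxy on an aromatic carbon, which is large and ends at a limit (the limit of > 100000 nM in this assay, at which 1 of the 3 values shown sits). Among the compounds with values here, no measured step replaces the nitro itself, so the expectation rests on an at least 100-fold higher number from compound 1 to compound 2 (2.00 log units; beyond the scatter), which shows that one change on this ring can move the number far. In this assay a step beyond the scatter is expected, towards a lower number and smaller than that one. The expected step is a 5.0-fold lower number from compound 1 to compound 4 (0.70 log units; beyond the scatter). For compound 4 the estimate is 200 nM, with an expected range from 20 nM to 2000 nM.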

Compound 4, half-maximal inhibitory concentration: 100 nM
For compound 4 the middle estimate is 2.0-fold (0.30 log units) above the measured one; the measured number falls inside the stated range.
By their numbers in this assay, from the lowest: compound 4; then compound 1; then compound 3. At a limit, above all of these: compound 2.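

In this assay, the nitro on this aromatic carbon, ortho to a methoxy group, proves not to be required, and exchanging it for amino gives a 10-fold lower number from compound 1 to compound 4 (1.00 log units; beyond the scatter). Until now, only the loss of the methoxy group had been seen to move the number on this ring, whereas this step shows that the group at this position can also be changed with a gain. Nothing measured here gives a cause for this step.

The compounds shown leave open whether a hydroxyl, an acetamide or a dimethylamino group on this carbon would match amino. They also leave open whether amino would hold its number without the methoxy group.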